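Trifluoromethoxy Gives Way to Isopropylcarbonyl on the Fused Ring

The source may hold more compounds than are shown below. What is called first, only, known or untested is meant among the compounds shown, and "the series" means these compounds.

Compound 1 `CCn1c(CNc2ccccc2)nnc1SCC(=O)Nc1ccc(OC)cc1`: in an assay on isolated protein for inhibition of long-chain fatty acid transport protein 1 (Homo sapiens) (on this read-out lower numbers stand for stronger inhibition and higher numbers for weaker inhibition), compound 1 reaches only the assay limit, > 1000 nM.
Compound 2 `CCn1c(CNc2ccccc2)nnc1SCc1nc2cc(OC(F)(F)F)ccc2o1`: in this assay compound 2 gives 100 nM.

Compound 2 holds the only number shown. The other value, that of compound 1, is the limit of > 1000 nM in this assay, at which 1 of the 2 values shown sits. Compound 3 `CCn1c(CNc2ccccc2)nnc1SCc1nc2cc(C(=O)C(C)C)ccc2o1` differs from compound 2 by isopropylcarbonyl in place of trifluoromethoxy on an aromatic carbon. Among the measured compounds shown here, no measured step bears on this change, so only a modest step is expected, if anything toward weaker inhibition. Compound 3 is therefore estimated at 250 nM, between 60 nM and 1200 nM. The expected step is a 2.5-fold higher number from compound 2 to compound 3 (0.40 log units; beyond the scatter).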

Compound 3, half-maximal inhibitory concentration: 600 nM
Compound 3: middle estimate off by 2.4-fold (0.38 log units), on the low side, within the range that was stated.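

On the aromatic carbon meta to a fused ring and para to a fused ring, the group clearly matters in this assay: isopropylcarbonyl in place of trifluoromethoxy gives a 6.0-fold higher number from compound 2 to compound 3 (0.78 log units; beyond the scatter), although both groups hold the same number of heavy atoms and hydrogen-bond acceptors. Among the compounds shown here, this is the first measured change at this position, and compound 3 still gives a number rather than an assay limit. Nothing measured here accounts for the step. From the compounds shown here alone, whether the carbonyl or the isopropyl carries the change remains open, as does the response to an acetyl group, an amine or a carboxylic acid on this carbon.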